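The compounds below may be only part of what the source reports. "The series", "measured", "known", "first", "only" and "open" are said of these compounds alone.

Working notes on the aryloxyacetamide series. For the measured compounds named here, compound 1 `CCN(Cc1ccco1)C(=O)COc1ccc(C)cc1` is one of two compounds measured in an assay on HEK293 cells for agonist activity at transient receptor potential cation channel subfamily M member 8 (Homo sapiens), read by fluorescence and calcium flux, with a stated time of 15 min; a lower number here means that less compound is needed, a higher number that more compound is needed for the effect; in this assay compound 1 gives 489 nM, the highest of the two numbers. Compound 2 `CCN(Cc1cccs1)C(=O)COc1cc(C)ccc1O` differs from compound 1 in several places. In this assay compound 2 gives 24 nM, a lower number beyond the scatter. Compound 3 `CCN(Cc1cn[nH]c1)C(=O)COc1ccc(C)cc1` has not been measured yet and differs from compound 1 in one place: 1H-pyrazol-4-yl in place of furan-2-yl on a saturated chain carbon bound to an amide-type nitrogen. Going by the values given here, no step between measured compounds isolates this change, so the expectation rests only on the pair of values above, which do not test the 1H-pyrazol-4-yl group. In the absence of a shown step the estimate for compound 3 assumes a modest shift toward a higher number, a 1.6-fold higher number from compound 1 to compound 3 (0.21 log units; within the scatter), with the expected value for compound 3 in this assay at 800 nM, within a range of 250 nM to 3000 nM.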

Compound 3, half-maximal effective concentration: "active" (no number reported)
For compound 3 the study gives words and no number; no gap can be computed for the estimate.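

For the compounds shown here, compound 3 is reported only in words, as active, so no step from compound 1 to compound 3 can be read. The compounds shown leave open how the number for 1H-pyrazol-4-yl compares with that for furan-2-yl. No other data shown bear on this result.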